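Estimating cell tolerance of compound 4 from one number

The compounds below may be only part of what the source reports. "The series", "measured", "known", "first", "only" and "open" are said of these compounds alone.

Compound 1 (`CCCCOc1ccc(-c2cc(C(=O)O)ccc2C)cc1CNC(=O)c1ccc(C(F)(F)F)cc1`) offers no number to start from. In an ADME assay on OR6 cells (Chlorocebus aethiops) for cytotoxicity, read by WST assay, with a stated time of 72 h (a higher number here means that more compound is tolerated, a lower number that less compound is tolerated), compound 1 is recorded as "not determined" (no result reported) with no result reported. Compound 2 (`CCCCOc1ccc(-c2ccc(C)c(C(=O)O)c2)cc1CNC(=O)c1ccc(C(F)(F)F)cc1`) is in the same position, since compound 2 also reads "not determined" (no result reported) with no figure behind it. Compound 3 (`CCOc1ccc(-c2ccc(C(=O)O)cc2C)cc1CNC(=O)c1ccc(C(F)(F)F)cc1`) is the only one of the three with a measurement, and compound 3 gives 3900 nM in this assay as a lone reading that cannot show a trend.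

Compound 4 (`CCCCOc1ccc(-c2ccc(C(=O)O)cc2Cl)cc1CNC(=O)c1ccc(C(F)(F)F)cc1`) follows from compound 1 through one swap on an aromatic carbon (4-carboxy-2-chlorophenyl in place of 5-carboxy-2-methylphenyl on an aromatic carbon): 4-carboxy-2-chlorophenyl enters in place of 5-carboxy-2-methylphenyl. Both groups carry a carboxy group on a six-membered aromatic ring of carbon only, while a chlorine enters and a methyl leaves. The swap sits para to a butoxy group and meta to a large group.

Among the compounds with values here, no measured step shows how far such a swap moves the number. The expectation is no step beyond the usual scatter of this assay in either direction, starting from the level of compound 3 at 3900 nM as the only anchor. The expected value for compound 4 is 3500 nM (estimated range from 1300 nM to 10000 nM).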

Compound 4, half-maximal cytotoxic concentration: 3200 nM
The estimate for compound 4 lay 1.1-fold (0.04 log units) above the measured number; low and high end bracket the measured number.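

Within the data shown here, compound 1 carries no single number in this assay, so no step from compound 1 to compound 4 can be read. Going by these compounds, whether putting 4-carboxy-2-chlorophenyl in place of 5-carboxy-2-methylphenyl shifts cell tolerance at all therefore stays open. Nothing shown here offers an explanation for the value of compound 4.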